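From Fluorophenyl to Methylphenyl: Expected Lipophilicity

The source may report more compounds than this note shows. Statements on the series, on what has been measured and on what is new or still open speak of the compounds shown alone.

Compound 3 `C=CCc1ccc(OC(=O)c2ccc(F)cc2)c(OC)c1` gives 2.7 in a physicochemical assay for lipophilicity; a higher number here means a more lipophilic compound, a lower number a more polar compound. It stands level with compound 2 `C=CCc1ccc(OC(=O)c2ccccc2F)c(OC)c1`, which gives 2.7, and the two share the lowest of the three numbers. Compound 1 `C=CCc1ccc(OC(=O)c2ccc(Cl)cc2)c(OC)c1` gives 2.79; the step of a number 0.09 log units lower from compound 1 to compound 3 (within the scatter) stays within the scatter. Compound 4 `C=CCc1ccc(OC(=O)c2cccc(C)c2)c(OC)c1` differs from compound 3 in one place: 3-methylphenyl in place of 4-fluorophenyl on a carbonyl carbon. The measured steps that bear on this all exchange one group on the ring attached to the carbonyl: a number 0.09 log units lower from compound 1 to compound 2 (within the scatter), a number 0.09 log units lower from compound 1 to compound 3 (within the scatter) and no change at the digits printed from compound 2 to compound 3 (within the scatter), none beyond the scatter. The change to compound 4 is of the same kind, so the expected step of a number 0.15 log units higher from compound 3 to compound 4 (within the scatter) is small. Compound 4 is estimated at 2.85, with a range from 2.55 to 3.15.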

Compound 4, partition coefficient: 2.87
Estimate against measurement, compound 4: 0.02 log units below, and the stated range covers the measured number.
By their numbers in this assay, from the lowest: compounds 2, 3, 1 and 4 (each within the scatter of the next).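

Swapping a halogen-bearing ring for the carbon-only 3-methylphenyl at this position, on a carbonyl carbon, still leaves this assay within the scatter, whichever earlier compound it is compared with (a number 0.17 log units higher from compound 3 to compound 4 (within the scatter)), (a number 0.17 log units higher from compound 2 to compound 4 (within the scatter)), (a number 0.08 log units higher from compound 1 to compound 4 (within the scatter)). Across these four compounds, then, fluoro, chloro and methyl versions of this ring cannot be told apart by this measure. Nothing available explains why the numbers stay so close. Open, on these data alone, is whether an amine or a carboxylic acid on this ring would move the number beyond the scatter.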